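From methyl to cyclopropyl on an amine nitrogen

The source may hold more compounds than are shown below. What is called first, only, known or untested is meant among the compounds shown, and "the series" means these compounds.

Measured so far in an ADME assay on microsomes from liver (Homo sapiens) for metabolic stability, read by LC-MS, using NADPH, tested at 1 uM; a lower number here means that the compound disappears faster, a higher number that the compound lasts longer
Compound 1 `Cc1nc2c(N)ncnc2n1[C@@H]1O[C@H](CN(C)C/C=C\CNC(=O)OCc2ccccc2)[C@@H](O)[C@H]1O` gives 0.4 h
Compound 2 `CC(=O)NC/C=C\CN(C)C[C@H]1O[C@@H](n2cnc3c(N)ncnc32)[C@H](O)[C@@H]1O` gives > 1.5 h, a limit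
Compound 3 `Cc1nc2c(N)ncnc2n1[C@@H]1O[C@H](CN(C)C/C=C\CNC(=O)OC(C)(C)C)[C@H]2OC(C)(C)O[C@H]21` gives < 0.0417 h, a limit

Compound 3 has the shortest half-life of the three, and its < 0.0417 h is a limit, not a number. Compound 4 `Cc1nc2c(N)ncnc2n1[C@@H]1O[C@H](CN(C/C=C\CNC(=O)OC(C)(C)C)C2CC2)[C@H]2OC(C)(C)O[C@H]21` differs from it by cyclopropyl in place of methyl on an amine nitrogen, with cyclopropyl in place of methyl on an amine nitrogen. Going by the values given here, no measured pair shows what this change does in this assay. The expected step that the limit leaves unreadable from compound 3 to compound 4 is estimated to stay within the usual scatter, in neither direction. Compound 4 is expected at 0.04 h, with an estimated range from 0.02 h to 0.1 h.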

Compound 4, half-life: < 0.0417 h
Compound 4 ended at the assay's limit; the forecaster's own chance of this, stated with the estimate: 70%; the middle value is on the limit's open side.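

In this assay, going by these compounds alone, compound 3 and compound 4 both end at a limit of the assay, and no step between them can be read. The compounds shown leave open what cyclopropyl in place of methyl on an amine nitrogen does to the half-life.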